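A longer amine chain on a core without measurable inhibition

This account rests on a few compounds, and the source may have more. Where it says the series, first, only, none or still open, it means among the compounds named here.

Compound 1, `CNc1nncc2cncn12`, gives in a functional assay for inhibition, with Homo sapiens as the target (on this read-out higher numbers stand for weaker inhibition and lower numbers for stronger inhibition), only the limit > 48000 nM.
Compound 2, `Sc1nncc2cncn12`, gives in this assay only the limit > 48000 nM.
Compound 3, `Oc1nncc2cncn12`, gives in this assay only the limit > 48000 nM.

Compound 1 therefore stands at a limit of this assay, not at a number, and its two companions stand at the same limit. The three steps that join them, a step that the two limits leave unreadable from compound 1 to compound 2, a step that the two limits leave unreadable from compound 1 to compound 3 and a step that the two limits leave unreadable from compound 2 to compound 3, cannot be read in size or direction, since each rests on two limits; this is summed up by the limit of > 48000 nM in this assay, at which 3 of the 3 values shown sit.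

The new compound 4, `CN(C)CCNc1nncc2cncn12`, differs from compound 1 by (dimethylamino)methyl in place of hydrogen on a saturated chain carbon bound to a nitrogen on an aromatic ring, so the methylamino group becomes a longer chain ending in a dimethylamino group. For the measured compounds named here, none of the measured steps touches this position, and all sit at the limit, so no size or direction can be taken from them. The expectation is that compound 4 stays at or near the limit, with a step that the limit leaves unreadable from compound 1 to compound 4 that cannot be distinguished from none. Compound 4 is estimated at 60000 nM, in a range from 15000 nM to 250000 nM.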

Compound 4, half-maximal inhibitory concentration: > 48000 nM
Compound 4: a limit, no number; the forecaster's own chance of this, stated with the estimate: 80%; the middle value is on the limit's open side.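

Compound 4, like compound 1, ends on a limit and not on a number, so the step between compound 1 and compound 4 cannot be read in size or in direction: the limit of > 48000 nM in this assay, at which 4 of the 4 values shown sit.

The compounds shown leave open whether any group on the shared core can bring measurable inhibition in this assay at all, and how strong it would be.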